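Swapping a fluoro for a methoxy on the pyrazole

The source may report more compounds than this note shows. Statements on the series, on what has been measured and on what is new or still open speak of the compounds shown alone.

Of the compounds shown here, three have been measured in an assay on cells for displacement of a labelled ligand from Glucagon receptor (Homo sapiens), in the presence of a further agent that is not named here; a higher number here means a weaker inhibitor, a lower number a stronger inhibitor. Compound 1, with the structure `CCCC(Oc1ccc(-n2cc(F)cn2)cc1)c1ccc(C(=O)NCCC(=O)O)cc1`, gives 1700 nM. Compound 2, with the structure `CCCC(Nc1ccc(-n2cc(C(F)(F)F)cn2)nc1)c1ccc(C(=O)NCCC(=O)O)cc1`, gives 170 nM. Compound 3, with the structure `CC(C)CC(Oc1ccc(-n2cc(C(F)(F)F)cn2)cc1)c1ccc(C(=O)NCCC(=O)O)cc1`, gives 549 nM. Compound 1 thus stands at the highest of the three numbers, which means it is the weakest of the three inhibitors; compound 2 and compound 3 each differ from compound 1 in more than one place, so no single change can be read from those gaps.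

The next compound, compound 4, has the structure `CCCC(Oc1ccc(-n2cc(OC)cn2)cc1)c1ccc(C(=O)NCCC(=O)O)cc1`. It differs from compound 1 only in one place: methoxy in place of fluoro on an aromatic carbon. Within the data shown here, no measured pair shows what this particular change does, so the expectation rests on compound 1 alone. The step from compound 1 to compound 4 is expected to be small, a 1.3-fold lower number from compound 1 to compound 4 (0.12 log units; within the scatter), and it may well stay within the scatter in either direction. On that basis compound 4 is estimated at 1300 nM, within a range of 450 nM to 4000 nM.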

Compound 4, inhibition constant: 4400 nM
The estimate for compound 4 lay 3.4-fold (0.53 log units) below the measured number, and the stated range ends below it.
By their numbers in this assay, from the lowest: compound 2; then compound 3; then compound 1; then compound 4.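

In this assay, putting methoxy in place of fluoro on this carbon of the five-membered ring gives a 2.6-fold higher number from compound 1 to compound 4 (0.41 log units; beyond the scatter) and so a weaker inhibitor. Among these compounds, this is the first change that can be read on its own, and it shows that this position is not indifferent to its group: one swap, with the rest of the structure held, moves the number beyond the usual scatter. Nothing measured here explains the loss.

With a single pair, there is no trend across groups at this carbon, and the trifluoromethyl of compound 2 and compound 3 cannot be compared directly with fluoro or methoxy because those compounds differ in other places as well. On these data alone, how a chlorine, a nitrile or an ethoxy would fare on this carbon of the core of compound 1 remains open.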